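The source may report more compounds than this note shows. Statements on the series, on what has been measured and on what is new or still open speak of the compounds shown alone.

Measured compounds in a functional assay on UACC-62 cells (Homo sapiens) for inhibition, read by sulforhodamine B assay, with a stated time of 48 h; a lower number here means a stronger inhibitor of growth, a higher number a weaker inhibitor of growth:
- compound 1, `CC1=CC[C@H](C(C)(C)NC(=S)NN)CC1`: in this assay compound 1 gives "not determined" (no result reported)
- compound 2, `COc1ccc(/C=N/NC(=S)NC(C)(C)[C@H]2CC=C(C)CC2)cc1`: in this assay compound 2 gives 13300 nM

Within the data shown here, compound 2 is the only entry with a number in this assay; compound 1 carries no result, so there is nothing to set compound 2 against, and it stands alone rather than high or low.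

Compound 3, `CC1=CC[C@H](C(C)(C)NC(=S)N/N=C/c2ccc(F)cc2)CC1`, is the next step from compound 2. The change is fluoro in place of methoxy on an aromatic carbon, para to a large group. Among the measured compounds shown here, no pair of measured compounds shows a step of this kind, so the size of the step in this assay has no measured precedent here. The expectation is a small step, most likely within the usual scatter, with a slight lean toward a weaker inhibitor than compound 2 as the more probable side of that scatter. The step from compound 2 to compound 3 is thus estimated at a 1.2-fold higher number from compound 2 to compound 3 (0.08 log units; within the scatter).

For compound 3 the estimated value in this assay is 16000 nM, with a range from 5000 nM to 50000 nM.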

Compound 3, concentration for 50% growth inhibition: > 100000 nM
Compound 3 gave a limit, no number; the forecaster's own chance of this, stated with the estimate: 25%; at least 6.2-fold (0.79 log units) between middle value and limit.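

Among these compounds, at this position, on an aromatic carbon para to a large group, the choice of substituent matters in this assay: going from 4-methoxyphenyl to 4-fluorophenyl gives an at least 7.5-fold higher number from compound 2 to compound 3 (0.87 log units; beyond the scatter), the only step that can be read, and it was not foreseeable from the earlier compounds, which offered no comparison at all. Compound 3 gives > 100000 nM, which is a limit of the assay and not a number. The step is therefore a lower bound with no known size, and the measurable growth inhibition in this pair rests with the methoxy compound alone: the limit of > 100000 nM in this assay, at which 1 of the 3 values shown sits.

A single pair cannot separate the effect of losing methoxy from that of gaining fluoro, and the compounds shown do not tell how an unsubstituted phenyl, a hydroxy or a dimethylamino group would read at the same place. From the compounds shown here alone, compound 1 gives "not determined" (no result reported) in this assay, so what the 4-methoxyphenyl part adds to the shared core also stays open.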